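The source may report more compounds than this note shows. Statements on the series, on what has been measured and on what is new or still open speak of the compounds shown alone.

Measured compounds:
- compound 1 `CCOC(=O)C1CCN(CCCOc2cc3ncnc(Nc4ccc(C#N)cc4)c3cc2OC)CC1`: 47200 nM
- compound 2 `COc1cc2c(Nc3ccc(C#N)cc3)ncnc2cc1OCCCN1CCC(N(C)C)CC1`: 24300 nM

In a functional assay on SH-SY5Y cells (Homo sapiens) for antiproliferative activity, read by MTT assay, with a stated time of 72 h (a lower number here means a stronger inhibitor, a higher number a weaker inhibitor), compound 1 gives 47200 nM and compound 2 gives 24300 nM. The only measured step, a 1.9-fold lower number from compound 1 to compound 2 (0.29 log units; within the scatter), lies within the scatter, so on the numbers shown compound 2 stands level with compound 1 and the pair gives no resolved trend for substitution at this saturated ring carbon.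

Compound 3 `COc1cc2c(Nc3ccc(C#N)cc3)ncnc2cc1OCCCN1CCN(c2ccncc2)CC1` remains to be measured in this assay. It differs from compound 2 by 4-(pyridin-4-yl)piperazin-1-yl in place of 4-(dimethylamino)piperidin-1-yl on a saturated chain carbon, three bonds along the chain from an oxygen on an aromatic ring. Among the measured compounds shown here, no measured step touches this change: the one step available, from compound 1 to compound 2, exchanges a group on the piperidine and says nothing about replacing the whole 4-(dimethylamino)piperidin-1-yl by a 4-(pyridin-4-yl)piperazin-1-yl. Both measured compounds sit in the same weak region of this assay, and without a bearing step the expectation for compound 3 is a number near that of compound 2, with no step beyond the scatter, that is a 1.1-fold higher number from compound 2 to compound 3 (0.03 log units; within the scatter).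

Compound 3 is therefore estimated at 26000 nM, in the range 8000 nM to 85000 nM.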

Compound 3, half-maximal inhibitory concentration: 31600 nM
Compound 3: middle estimate off by 1.2-fold (0.08 log units), on the low side; measured number inside the range.
By their numbers in this assay, from the lowest: compounds 2, 3 and 1 (each within the scatter of the next).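

In this assay, the group on the saturated chain carbon, three bonds along the chain from an oxygen on an aromatic ring, has now been exchanged as a whole, and 4-(pyridin-4-yl)piperazin-1-yl in place of 4-(dimethylamino)piperidin-1-yl gives a 1.3-fold higher number from compound 2 to compound 3 (0.11 log units; within the scatter), while the same group in place of 4-(ethoxycarbonyl)piperidin-1-yl gives a 1.5-fold lower number from compound 1 to compound 3 (0.17 log units; within the scatter). Both steps lie within the scatter, so even a change that adds an aromatic ring and a further ring nitrogen leaves compound 3 level with compound 1 and compound 2, and the earlier finding for a single substituent on the piperidine now extends to replacement of the whole group. No measurement is available that would account for this level reading.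

The compounds shown leave open whether any group at this place can move the number beyond the scatter, or whether all three readings are set by the shared core. A carboxylic acid on the piperidine, a morpholine in place of the piperazine, or a longer chain carrying the same 4-(pyridin-4-yl)piperazin-1-yl would each test this further.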